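Swapping an End Group at the Assay Limit

This account rests on a few compounds, and the source may have more. Where it says the series, first, only, none or still open, it means among the compounds named here.

In a functional assay on K562 cells (Homo sapiens) for antiproliferative activity, read by MTT assay, with a stated time of 48 h (on this read-out higher numbers stand for weaker inhibition and lower numbers for stronger inhibition), compound 2 (`COc1cc(CNC(=O)CCCCCCC(C)C)ccc1OCCCCCOc1ccc(C(N)=S)cc1`) gives only a limit, > 50000 nM. This is one of two results at that limit, as the limit of > 50000 nM in this assay, at which 2 of the 2 values shown sit, shows. Compound 3 (`COc1cc(CNC(=O)CCCCCCC(C)C)ccc1OCCCCCOc1ccc(-c2cc(=S)ss2)cc1`) differs from compound 2 by a group of 6 heavy atoms (3 carbon, 3 sulfur; one five-membered aromatic ring with 2 hetero atoms) in place of a group of 3 heavy atoms (1 carbon, 1 nitrogen, 1 sulfur; no ring), on an aromatic carbon. Compound 1 (`COc1cc(CNC(=O)CCCC/C=C/C(C)C)ccc1OCCCCCOc1ccc(-c2cc(=S)ss2)cc1`), which already bears a five-membered aromatic ring with 2 hetero atoms, also gives only a limit, > 50000 nM. For the measured compounds named here, no measured step shows the effect of this swap, so only a small change, none beyond the scatter, is expected in this assay, namely a number no higher from compound 2 to compound 3 (the limit leaves the size open). For compound 3 the estimated value is 50000 nM, with an expected range of 20000 nM to 100000 nM.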

Compound 3, half-maximal inhibitory concentration: > 50000 nM
Compound 3 was reported as a limit; the forecaster's own chance of this, stated with the estimate: 80%; the middle value lies on the limit itself.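

In this assay compound 3 gives only a limit, as compound 1 and compound 2 do, so neither step to compound 3 can be read: the limit of > 50000 nM in this assay, at which 3 of the 3 values shown sit.
The compounds shown leave open how these three rank against one another.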